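Methylating a Ring Nitrogen of the Shared Core

The compounds below may be only part of what the source reports. "The series", "measured", "known", "first", "only" and "open" are said of these compounds alone.

Compound 1 `COc1ccc(-c2cc3[nH]nc(N)c3c(=O)[nH]2)cc1` is one of three compounds tested in an assay on isolated protein for inhibition of ribosomal protein S6 kinase alpha-1 (Homo sapiens), read by mobility shift assay, tested at 30 uM; a higher number here means more inhibition at the concentration tested (going by the name of the read-out), a lower number less inhibition. In this assay compound 1 gives 7%, the second highest of the three numbers. For the measured compounds named here, compound 2 `CN1CCN(c2ccc(-c3cc4[nH]nc(N)c4c(=O)[nH]3)cc2)CC1` carries a 4-methylpiperazin-1-yl in place of the methoxy on an aromatic carbon, and in this assay compound 2 gives 26%; the step of a number 19 percentage points higher from compound 1 to compound 2 (beyond the scatter) is the only change in the set that goes beyond the scatter. Compound 3 `Cc1cc2c(c(N)nn2C)c(=O)[nH]1` differs from compound 1 in two places at once, and in this assay compound 3 gives 2%, a number within the scatter of compound 1.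

Compound 4 `COc1ccc(-c2cc3c(c(N)nn3C)c(=O)[nH]2)cc1` has not yet been measured. It differs from compound 1 in one place: methyl in place of hydrogen on an aromatic nitrogen. The methyl enters on an aromatic nitrogen of a five-membered aromatic ring with 2 nitrogen, part of the fused system of two rings that forms the shared core. Going by the values given here, no measured step isolates this change. Among the compounds with values here, compound 3 carries a methyl on the same ring nitrogen but also a different group elsewhere, so its value shows only that a compound bearing this methyl can sit within the scatter of compound 1. Within the data shown here, the one measured step, from compound 1 to compound 2, concerns a different position and does not bear on this change. The expectation is therefore no step beyond the scatter, an estimated step of a number 2 percentage points lower from compound 1 to compound 4 (within the scatter). Compound 4 is estimated to give 5% in this assay, within a range from -5% to 15%.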

Compound 4, a percentage reported as inhibition, at one concentration (the size of the read-out at that concentration, not a potency): 18%
Beside the measured number, compound 4's estimate is 13 percentage points below it; measured number outside the range, above it.
By their numbers in this assay, from the lowest: compounds 3 and 1 (each within the scatter of the next); then compounds 4 and 2 (each within the scatter of the next).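

In this assay, for the compounds shown here, compound 4 isolates the methyl for the first time, and this single change gives a number 11 percentage points higher from compound 1 to compound 4 (beyond the scatter) in a step described as modest. The hydrogen on this aromatic nitrogen is therefore not required for the inhibition seen at the concentration tested, and a methyl can stand there with the number rising rather than falling. Compound 3, which carries the same methyl, gives 2%, so the presence of this methyl does not by itself hold the number low, and no measurement shown here explains why adding it raises the number.

On these data alone, it remains open whether the gain is particular to methyl or would persist with an ethyl group, a longer chain such as n-propyl, or a chain ending in an amine on the same nitrogen. Also open, as far as these compounds go, is whether the methyl on this nitrogen and the 4-methylpiperazin-1-yl group would add together in one compound, since each has been seen only apart from the other on the shared core, and a single reading at one concentration does not give a potency.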